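Aryl Swap on the Carbamate Nitrogen of a Shared Core

The compounds below may be only part of what the source reports. "The series", "measured", "known", "first", "only" and "open" are said of these compounds alone.

The compounds share one core and differ only in the aryl group on an amide-type nitrogen. Compound 1 `CC(C)=CCC/C(C)=C/CC1Cc2c(OC(=O)Nc3ccccc3F)cc(=O)n(CCCO)c2CC1(C)C` carries 2-fluorophenyl there, and in a functional assay on PANC-1 cells (Homo sapiens) for inhibition, read by MTT assay, with a stated time of 24 h, tested at 10 uM (a higher number here means more inhibition at the concentration tested (going by the name of the read-out), a lower number less inhibition), compound 1 gives 71.6%. Compound 2 `CC(C)=CCC/C(C)=C/CC1Cc2c(OC(=O)Nc3ccc(Cl)cc3)cc(=O)n(CCCO)c2CC1(C)C` carries 4-chlorophenyl, and in this assay compound 2 gives 47.2%. For the measured compounds named here, compound 2 thus stands lowest of the two numbers measured so far, separated from compound 1 by a step that is a number 24.4 percentage points lower from compound 1 to compound 2 (beyond the scatter), beyond the scatter yet modest.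

Compound 3 `CC(C)=CCC/C(C)=C/CC1Cc2c(OC(=O)Nc3cccc(C(F)(F)F)c3)cc(=O)n(CCCO)c2CC1(C)C` awaits measurement. It differs from compound 2 by 3-(trifluoromethyl)phenyl in place of 4-chlorophenyl on an amide-type nitrogen. Going by the values given here, the only measured step that bears on this change is the earlier aryl swap on the same nitrogen, which gave a number 24.4 percentage points lower from compound 1 to compound 2 (beyond the scatter). That step shows the aryl group can move the read-out by a modest amount, but nothing measured here tells which way a change from 4-chlorophenyl to 3-(trifluoromethyl)phenyl will go. The expected step is therefore a number 6.8 percentage points higher from compound 2 to compound 3 (within the scatter), within the scatter. For compound 3 the estimate in this assay is 54%, between 34% and 74%.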

Compound 3, a percentage reported as inhibition, at one concentration (the size of the read-out at that concentration, not a potency): 44%
Compound 3: middle estimate off by 10 percentage points, on the high side; measured number inside the range.
By their numbers in this assay, from the lowest: compounds 3 and 2 (each within the scatter of the next); then compound 1.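

In this assay, the change from 4-chlorophenyl to 3-(trifluoromethyl)phenyl on the amide-type nitrogen gives a number 3.2 percentage points lower from compound 2 to compound 3 (within the scatter), so this read-out does not separate these two aryl groups at the concentration tested, even though the entering group has 10 heavy atoms against 7 for the group it replaces. The step of a number 27.6 percentage points lower from compound 1 to compound 3 (beyond the scatter) runs the same way as the earlier step of a number 24.4 percentage points lower from compound 1 to compound 2 (beyond the scatter), which now makes compound 1, with its 2-fluorophenyl, the highest of the three and leaves compound 2 and compound 3 together as a pair below it. Nothing available explains why the 2-fluorophenyl group stands apart from the other two aryl groups.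

The three compounds leave open whether the higher number of compound 1 goes with the fluorine itself or with where it sits on the ring, as its aryl group differs from the other two in both. They also leave open how an unsubstituted phenyl, or an aryl group carrying an amine or a carboxylic acid, would read on the same nitrogen of the shared core.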